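Hydroxymethyl on the Piperidine Across Two Linker Lengths

This account rests on a few compounds, and the source may have more. Where it says the series, first, only, none or still open, it means among the compounds named here.

Compound 1 `COc1ccc(-c2cc(=O)c3ccc(OCCCN4CCC(C)CC4)cc3o2)cc1` and compound 2 `COc1ccc(-c2cc(=O)c3ccc(OCCCN4CCC(CCO)CC4)cc3o2)cc1` share a core and differ by hydroxymethyl in place of hydrogen on a saturated chain carbon bound to a saturated ring carbon. In a functional assay for inhibition, read by fluorescence and spectrophotometry, with a stated time of 30 h (on this read-out higher numbers stand for weaker inhibition and lower numbers for stronger inhibition), compound 1 gives 42600 nM, and compound 2 gives 43200 nM, so the step of a 1.0-fold higher number from compound 1 to compound 2 (0.01 log units; within the scatter). Compound 3 `COc1ccc(-c2cc(=O)c3ccc(OCCCCCCN4CCC(C)CC4)cc3o2)cc1` differs from compound 1 by 3-(4-methylpiperidin-1-yl)propyl in place of 4-methylpiperidin-1-yl on a saturated chain carbon, three bonds along the chain from an oxygen on an aromatic ring, and in this assay compound 3 gives 57200 nM, a step of a 1.3-fold higher number from compound 1 to compound 3 (0.13 log units; within the scatter). Compound 4 `COc1ccc(-c2cc(=O)c3ccc(OCCCCCCN4CCC(CCO)CC4)cc3o2)cc1` is not yet measured; it differs from compound 3 by hydroxymethyl in place of hydrogen on a saturated chain carbon bound to a saturated ring carbon, the same change as from compound 1 to compound 2, at the same place. Because a 1.0-fold higher number from compound 1 to compound 2 (0.01 log units; within the scatter) stayed within the scatter, the step of a 1.0-fold higher number from compound 3 to compound 4 (0.01 log units; within the scatter) is expected to be about as small. Compound 4 is therefore estimated at 58000 nM in this assay, with a likely range from 30000 nM to 110000 nM.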

Compound 4, half-maximal inhibitory concentration: 50400 nM
The estimate for compound 4 lay 1.2-fold (0.06 log units) above the measured number, and the stated range covers the measured number.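

In this assay, the hydroxymethyl change on the core of compound 3 gives a 1.1-fold lower number from compound 3 to compound 4 (0.05 log units; within the scatter). Set beside the earlier step, the change carries over from one core to the other without a detectable difference: the same change on two cores in this assay, a 1.0-fold higher number (0.01 log units; within the scatter) from compound 1 to compound 2 and a 1.1-fold lower number (0.05 log units; within the scatter) from compound 3 to compound 4, 1.2-fold (0.06 log units) apart, within the scatter of two such steps This shows only that the step stays small on these two cores; two cores are too few to make a rule, and the result does not show that the step would stay small on other cores in this series.

The compounds shown leave open what an amine or a carboxylic acid would do in place of the hydroxymethyl. They also leave open whether the step would stay as small with a longer chain joining the piperidine to the core.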